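Cyclohexyl on the Ring Nitrogen of Compound 1

The compounds below may be only part of what the source reports. "The series", "measured", "known", "first", "only" and "open" are said of these compounds alone.

Among the compounds with values here, compound 1 `O=C1COc2ccc(-c3cccc(NS(=O)(=O)c4ccc(F)cc4)c3)cc2N1` keeps a bare hydrogen on its amide-type nitrogen, and in a functional assay on A549 cells (Homo sapiens) for antiproliferative activity, read by MTT assay, with a stated time of 72 h (on this read-out lower numbers stand for stronger inhibition and higher numbers for weaker inhibition), compound 1 gives 32100 nM, the highest of the three numbers so far. Compound 3 `COc1ncc(-c2ccc3c(c2)N(c2ccc(Cl)cc2)C(=O)CO3)cc1NS(=O)(=O)c1ccc(F)cc1` gives 8350 nM, and compound 2 `COc1ccc(N2C(=O)COc3ccc(-c4cnc(OC)c(NS(=O)(=O)c5ccc(F)cc5)c4)cc32)cc1` gives 1350 nM. Compound 4 `O=C1COc2ccc(-c3cccc(NS(=O)(=O)c4ccc(F)cc4)c3)cc2N1C1CCCCC1` makes one change to compound 1: cyclohexyl in place of hydrogen on an amide-type nitrogen in a ring.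

Compound 2 and compound 3 both carry a group on that nitrogen and both sit lower than compound 1, but they also differ from it elsewhere, so neither offers a clean comparison. Within the data shown here, the only measured step, a 6.2-fold higher number from compound 2 to compound 3 (0.79 log units; beyond the scatter), shows that swapping chloro for methoxy on an aromatic carbon can move the number beyond the scatter. Among the measured compounds shown here, no measured compound has a cyclohexyl group, so the expectation is loose: a moderately lower number in this assay, though no change at all remains possible. The estimated step is a 3.6-fold lower number from compound 1 to compound 4 (0.55 log units; beyond the scatter). For compound 4 the expected value is 9000 nM, with an estimated range from 2500 nM to 32000 nM.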

Compound 4, half-maximal inhibitory concentration: 14500 nM
Compound 4: the middle estimate sits 1.6-fold (0.21 log units) below what was measured; measured number inside the range.
By their numbers in this assay, from the lowest: compound 2; then compounds 3 and 4 (each within the scatter of the next); then compound 1.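

Within the data shown here, this is the first clean reading at the ring nitrogen: in this assay there is a 2.2-fold lower number from compound 1 to compound 4 (0.35 log units; beyond the scatter) and nothing else in the molecule changes. The step is modest but beyond the scatter, so the amide-type nitrogen does not need its bare hydrogen for this activity, and a non-aromatic ring of carbon can sit there. Nothing available on these compounds explains why the number moves.

On these data alone, it remains open whether a smaller group such as methyl, or a cyclohexyl ring carrying an amine or a carboxylic acid, would lower the number further or raise it again. The compounds shown also leave open whether cyclohexyl on this nitrogen would give a step of similar size on the core of compound 2.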